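The source may hold more compounds than are shown below. What is called first, only, known or untested is meant among the compounds shown, and "the series" means these compounds.

Measured in a functional assay on MDA-MB-468 cells (Homo sapiens) for inhibition, read by sulforhodamine B assay, with a stated time of 48 h; a lower number here means a stronger inhibitor of growth, a higher number a weaker inhibitor of growth:

compound 1 `COc1cc(C)cc(-c2c(-c3ccnc(-c4ccc(C(C)=O)cc4)c3)cnn2CC#N)c1` gives 1430 nM
compound 2 `Cc1cc(O)cc(-c2nn(CC#N)cc2-c2ccnc(-c3ccc(Oc4ccccc4)cc3)c2)c1` gives 1790 nM
compound 3 `COc1cc(C)cc(-c2nn(CC#N)cc2-c2ccnc(-c3ccc(N(C)C)cc3)c2)c1` gives 181 nM

Of these three, compound 3 gives the lowest number, and its gap to each of the other two lies beyond the usual scatter, so it is the strongest growth inhibitor of the set. Compound 4 `Cc1cc(O)cc(-c2nn(CC#N)cc2-c2ccnc(-c3ccc(N(C)C)cc3)c2)c1` has not yet been measured in this assay. It differs from compound 3 in one place: hydrogen in place of methyl on an oxygen on an aromatic ring. Among the compounds with values here, no pair already measured shows this same change on its own, since compounds 1 and 2 also differ in their outer aryl groups, so the size of this step is open. A small change is expected, if any beyond the scatter, leaning toward a weaker inhibitor; the step from compound 3 to compound 4 is estimated at a 1.8-fold higher number from compound 3 to compound 4 (0.25 log units; within the scatter). For compound 4 the expected value in this assay is 320 nM, within a range from 100 nM to 1000 nM.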

Compound 4, concentration for 50% growth inhibition: 1630 nM
Beside the measured number, compound 4's estimate is 5.1-fold (0.71 log units) below it; measured number outside the range, above it.
By their numbers in this assay, from the lowest: compound 3; then compounds 1, 4 and 2 (each within the scatter of the next).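

Removing the methyl from the methoxy group of compound 3 is not a minor edit at this position on the aromatic ring: the change gives a 9.0-fold higher number from compound 3 to compound 4 (0.95 log units; beyond the scatter) and so costs most of the growth inhibition. With hydroxy kept, dimethylamino in place of phenoxy gives a 1.1-fold lower number from compound 2 to compound 4 (0.04 log units; within the scatter) and so brings no gain on its own. Among these compounds, only compound 3 combines methoxy with dimethylamino and gives the low number.

As far as these compounds go, whether ethoxy or an amine at this position would retain that strength remains open. No measurement here explains the loss on going from methoxy to hydroxy.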